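Replacing the carbamoyl in a nitrobenzofuran amide

The source may hold more compounds than are shown below. What is called first, only, known or untested is meant among the compounds shown, and "the series" means these compounds.

Measured so far:
compound 1, `NC(=O)c1ccccc1NC(=O)c1cc2cc([N+](=O)[O-])ccc2o1`, 5 ug/mL
compound 2, `NCc1ccccc1NC(=O)c1cccc2ccccc12`, 25 ug/mL

In a physicochemical assay for solubility (a lower number here means a less soluble compound, a higher number a more soluble compound), compound 1 gives 5 ug/mL, the lowest of the two numbers. The nearest point is compound 2, whose number is higher by a margin beyond the usual scatter.

Compound 3, `CC(C)(C)OC(=O)NCc1ccccc1NC(=O)c1cc2cc([N+](=O)[O-])ccc2o1`, is not yet measured. It differs from compound 1 in one place: ((tert-butoxycarbonyl)amino)methyl in place of carbamoyl on an aromatic carbon, ortho to a large group. Among the compounds with values here, no measured pair shows this exact change, so the size of the step is uncertain.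

The step from compound 1 to compound 3 in this assay is expected to be a 1.7-fold lower number from compound 1 to compound 3 (0.22 log units; within the scatter), a modest move downward or none beyond the scatter. Compound 3 is therefore estimated at 3 ug/mL, within a range from 1 ug/mL to 10 ug/mL.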

Compound 3, solubility: 25 ug/mL
Estimate against measurement, compound 3: 8.3-fold (0.92 log units) below; measured number above the stated range.
By their numbers in this assay, from the lowest: compound 1; then compounds 2 and 3 (each within the scatter of the next).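

In this assay, ((tert-butoxycarbonyl)amino)methyl in place of carbamoyl gives a 5.0-fold higher number from compound 1 to compound 3 (0.70 log units; beyond the scatter). Within the data shown here, this is the first comparison here between compounds that differ in one place, and it shows that on this aromatic carbon a group of 9 heavy atoms instead of 3 goes with a higher number, not a lower one. Nothing available here accounts for the rise.

A single step cannot show which part of the entering group matters, the tert-butoxycarbonyl end or the methyl link to the ring, nor whether the same holds on other cores. On these data alone, how a carboxylic acid, an amine attached directly to the ring or a longer carbon chain on this aromatic carbon would read in this assay also remains open.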